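A Trifluoromethyl Replaces the Phenol of Compound 2

A few compounds are considered here, and "the series" means these few. Any claim that something is new, unique, unknown or untested is made for them only; others in the source may bear on it.

Of the compounds shown here, two built on the same core have been measured in a functional assay on HCT-15 cells (Homo sapiens) for cytotoxicity; a lower number here means a stronger inhibitor of growth, a higher number a weaker inhibitor of growth. Compound 1 `COc1cccc(C#Cc2ccccc2C#CCCCCO)c1` gives 3600 nM. For the measured compounds named here, compound 2 `OCCCCC#Cc1ccccc1C#Cc1cccc(O)c1` gives 13600 nM, the higher of the two numbers; the only step between them, hydrogen in place of methyl on an oxygen on an aromatic ring, is a 3.8-fold higher number from compound 1 to compound 2 (0.58 log units; beyond the scatter). Compound 3 `OCCCCC#Cc1ccccc1C#Cc1cccc(C(F)(F)F)c1` differs from compound 2 by trifluoromethyl in place of hydroxy on an aromatic carbon. Going by the values given here, no measured step shares this change; the single step from compound 1 to compound 2 bears on it only in that it also removes or alters the group at the same place, and there a hydroxy replacing methoxy raised the number modestly. Compound 3 is therefore expected to show a step of about a 2.3-fold lower number from compound 2 to compound 3 (0.36 log units; beyond the scatter) in this assay, toward a lower number. The estimate for compound 3 is 6000 nM, with a range from 2000 nM to 18000 nM.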

Compound 3, concentration for 50% growth inhibition: 16300 nM
Compound 3: the middle estimate sits 2.7-fold (0.43 log units) below what was measured; low and high end bracket the measured number.
By their numbers in this assay, from the lowest: compound 1; then compounds 2 and 3 (each within the scatter of the next).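

In this assay, hydroxy and trifluoromethyl on this aromatic carbon, meta to a large group, cannot be told apart: the exchange gives a 1.2-fold higher number from compound 2 to compound 3 (0.08 log units; within the scatter), even though 1 heavy atom with 1 hydrogen-bond donor and 1 hydrogen-bond acceptor gives way to 4 heavy atoms with 0 of either. Methoxy alone stands apart among these three groups, with a 4.5-fold higher number from compound 1 to compound 3 (0.66 log units; beyond the scatter), so compound 1 remains the strongest inhibitor of growth of the three. Nothing available accounts for these numbers.

The compounds shown leave open whether any other group at this place would match or improve on methoxy, for example a longer ether such as ethoxy, or an amine. They also leave open whether methoxy would keep its edge over hydroxy and trifluoromethyl with a longer chain in place of the hydroxyl-ended chain of the shared core.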